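Swapping the aryl group for cyclopentyl on the shared core

The source may report more compounds than this note shows. Statements on the series, on what has been measured and on what is new or still open speak of the compounds shown alone.

Compound 3 `Clc1ccccc1-c1nc(NCc2ccc(-c3cccnc3)cc2)c2ccccc2n1` gives 2100 nM in an assay on a protein complex for inhibition of ubiquitin carboxyl-terminal hydrolase 1/WD repeat-containing protein 48 (Homo sapiens), read by fluorescence (a higher number here means a weaker inhibitor, a lower number a stronger inhibitor), the highest of the two numbers measured; compound 2 `CCc1ccccc1-c1nc(NCc2ccc(-c3cccnc3)cc2)c2ccccc2n1` gives 780 nM, and compound 1 `FC(F)(F)c1ccc(-c2nc(NCc3ccc(-c4cccnc4)cc3)c3ccccc3n2)cc1` is reported as "not active" (no number reported). Within the data shown here, the only measured step, a 2.7-fold higher number from compound 2 to compound 3 (0.43 log units; beyond the scatter), changes a group on the aryl ring rather than replacing the ring. Among the measured compounds shown here, compound 4 `c1cncc(-c2ccc(CNc3nc(C4CCCC4)nc4ccccc34)cc2)c1` differs from compound 3 by cyclopentyl in place of 2-chlorophenyl on an aromatic carbon, a change with no direct precedent here, so the direction is uncertain. A modest weakening is expected, a 1.7-fold higher number from compound 3 to compound 4 (0.22 log units; within the scatter), with a wide range because only a 2.7-fold higher number from compound 2 to compound 3 (0.43 log units; beyond the scatter) is available for guidance. Compound 4 is therefore estimated at 3500 nM, between 800 nM and 15000 nM.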

Compound 4, half-maximal inhibitory concentration: "not active" (no number reported)
The entry for compound 4 holds no number; no gap can be computed for the estimate.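

In this assay, among these compounds, compound 4 reads "not active" (no number reported) so no step from compound 3 can be read, and no supporting data bear on this result. The compounds shown leave open how much weaker compound 4 is than compound 3.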